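A few compounds are considered here, and "the series" means these few. Any claim that something is new, unique, unknown or untested is made for them only; others in the source may bear on it.

Working notes on the series. The shared core appears in compound 1 `Cc1ccc(-c2nn(-c3cccc(Cl)c3)cc2C(=O)Nc2ccc(C)c(S(=O)(=O)N3CCOCC3)c2)cc1`, compound 2 `Cc1ccc(-c2nn(CC3CC3)cc2C(=O)Nc2ccc(C)c(S(=O)(=O)N3CCOCC3)c2)cc1` and compound 3 `Cc1ccc(-c2nn(CCCCO)cc2C(=O)Nc2ccc(C)c(S(=O)(=O)N3CCOCC3)c2)cc1`, which differ only in the group on the aromatic nitrogen. In an assay on HEK-293T cells for inhibition of Bile acid receptor (Homo sapiens), read by a beta-lactamase reporter, with a stated time of 16 h (on this read-out higher numbers stand for weaker inhibition and lower numbers for stronger inhibition), compound 1 gives 5910 nM, compound 2 gives 849 nM and compound 3 gives 2610 nM; compound 3 thus stands second highest of the three, with a 3.1-fold higher number from compound 2 to compound 3 (0.49 log units; beyond the scatter) and a 2.3-fold lower number from compound 1 to compound 3 (0.35 log units; beyond the scatter). Compound 4 `Cc1ccc(-c2nn(-c3ccccc3)cc2C(=O)Nc2ccc(C)c(S(=O)(=O)N3CCOCC3)c2)cc1` carries phenyl in place of 4-hydroxybutyl on an aromatic nitrogen. The step from compound 1 to compound 3 is the one that bears on this change, as it exchanges another aromatic ring on that nitrogen for the same chain; run in reverse it points toward a higher number of modest size. Compound 4 is therefore expected to give 5000 nM in this assay, with a range of 1800 nM to 14000 nM, an expected step of a 1.9-fold higher number from compound 3 to compound 4 (0.28 log units; within the scatter).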

Compound 4, half-maximal inhibitory concentration: 2620 nM
Compound 4: middle estimate off by 1.9-fold (0.28 log units), on the high side; measured number inside the range.
By their numbers in this assay, from the lowest: compound 2; then compounds 3 and 4 (each within the scatter of the next); then compound 1.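

In this assay, phenyl and 4-hydroxybutyl on the aromatic nitrogen cannot be told apart, with a 1.0-fold higher number from compound 3 to compound 4 (0.00 log units; within the scatter), so an aromatic ring and an open hydroxyl-bearing chain read alike here. Hydrogen in place of chloro on the aromatic carbon gives a 2.3-fold lower number from compound 1 to compound 4 (0.35 log units; beyond the scatter), showing that the ring substituent also matters, while phenyl in place of cyclopropylmethyl gives a 3.1-fold higher number from compound 2 to compound 4 (0.49 log units; beyond the scatter). No measurement on hand explains these steps. Open, going by these compounds, is whether fluoro or methoxy on the phenyl ring would track with chloro, and whether a cyclobutylmethyl group would extend the result for cyclopropylmethyl.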